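Swapping the para fluoro for chloro on the phenylpiperazine

A few compounds are considered here, and "the series" means these few. Any claim that something is new, unique, unknown or untested is made for them only; others in the source may bear on it.

Compound 2 `O=C1CC(c2ccccc2F)C(=O)N1CN1CCN(c2ccc(F)cc2)CC1` gives the lowest number of the two measured in a functional assay on the whole organism (strain CF-1 albino) with Mus musculus as the target, with a stated time of 4 h (a higher number here means that more compound is needed for the effect, a lower number that less compound is needed), namely 30 mg/kg. Compound 1 `O=C1CC(c2ccccc2F)C(=O)N1CN1CCN(c2ccccc2)CC1` gives 300 mg/kg in this assay, and the step of a 10-fold lower number from compound 1 to compound 2 (1.00 log units; beyond the scatter) lies beyond the scatter. Compound 3 `O=C1CC(c2ccccc2F)C(=O)N1CN1CCN(c2ccc(Cl)cc2)CC1` differs from compound 2 by chloro in place of fluoro on an aromatic carbon. Within the data shown here, no measured step swaps fluoro for chloro, so the only guide is that the halogen-bearing aryl already gave the lower number; compound 3 is therefore expected to change little, with no change at the digits printed from compound 2 to compound 3 (within the scatter) inside the scatter. Compound 3 is estimated at 30 mg/kg, between 10 mg/kg and 100 mg/kg.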

Compound 3, minimum effective dose: 100 mg/kg
Compound 3: middle estimate off by 3.3-fold (0.52 log units), on the low side; low and high end bracket the measured number.
By their numbers in this assay, from the lowest: compound 2; then compound 3; then compound 1.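

In this assay, the two halogens are not interchangeable on this carbon: chloro in place of fluoro gives a 3.3-fold higher number from compound 2 to compound 3 (0.52 log units; beyond the scatter) and so loses part of what fluoro gained. Chloro in place of hydrogen still gives a 3.0-fold lower number from compound 1 to compound 3 (0.48 log units; beyond the scatter) on the same ring, so among these three compounds, either halogen needs less compound than hydrogen, and fluoro needs the least. Nothing available here explains the gap between fluoro and chloro.

As far as these compounds go, whether bromo, methoxy or an amine on this carbon would give a lower number than fluoro stays open.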